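This account rests on a few compounds, and the source may have more. Where it says the series, first, only, none or still open, it means among the compounds named here.

Measured compounds:
- Compound 1, `COc1cc2ncnc(Nc3ccc(Cl)cc3)c2cc1OCCCCC(=O)Nc1ccc(S(N)(=O)=O)cc1`, gives 31800 nM.
- Compound 2, `COc1ccc(Nc2ncnc3cc(OC)c(OCCCCC(=O)Nc4ccc(S(N)(=O)=O)cc4)cc23)cc1OC`, gives 9230 nM.

Within the data shown here, in a functional assay on NCI-H1975 cells (Homo sapiens) for antiproliferative activity, read by MTT assay, with a stated time of 72 h (on this read-out lower numbers stand for stronger inhibition and higher numbers for weaker inhibition), compound 2 stands lowest of the two numbers; the only measured step, a 3.4-fold lower number from compound 1 to compound 2 (0.54 log units; beyond the scatter), is the whole of what is known about how a change at this position moves the read-out. Compound 3, `COc1cc2ncnc(Nc3ccc(F)c(Br)c3)c2cc1OCCCCC(=O)Nc1ccc(S(N)(=O)=O)cc1`, differs from compound 2 by 3-bromo-4-fluorophenyl in place of 3,4-dimethoxyphenyl on a nitrogen on an aromatic ring. That step has not been measured directly. Among the measured compounds shown here, the one step that bears on it shows that swapping the 4-chlorophenyl of compound 1 for the 3,4-dimethoxyphenyl of compound 2 lowered the number modestly, so returning to a phenyl that carries only halogen atoms is expected to move the number back up by a similar, modest amount, though a different pair of substituents may not behave like chlorine alone. Compound 3 is therefore expected to give 20000 nM, with a range from 6000 nM to 60000 nM, a step of a 2.2-fold higher number from compound 2 to compound 3 (0.34 log units; beyond the scatter).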

Compound 3, half-maximal inhibitory concentration: 31600 nM
Beside the measured number, compound 3's estimate is 1.6-fold (0.20 log units) below it; measured number inside the range.
By their numbers in this assay, from the lowest: compound 2; then compounds 3 and 1 (each within the scatter of the next).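

In this assay, moving to 3-bromo-4-fluorophenyl gives a 3.4-fold higher number from compound 2 to compound 3 (0.53 log units; beyond the scatter) and so takes away the gain seen with 3,4-dimethoxyphenyl. The two phenyls that carry only halogens cannot be told apart here, with a 1.0-fold lower number from compound 1 to compound 3 (0.00 log units; within the scatter), so swapping one chlorine for a bromine and fluorine pair makes no visible difference, and among these three compounds only the 3,4-dimethoxyphenyl of compound 2 stands apart. Nothing available explains why that group gives the lower number.

Going by these compounds, it stays open whether both methoxy groups are needed, or whether a single methoxy group on the phenyl would give the same number. Also open, on these data alone, is how a phenyl carrying an amine, a hydroxyl or a carboxylic acid would compare with these three.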